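From Trifluoromethyl to Chloro: Estimating Compound 4

The compounds below may be only part of what the source reports. "The series", "measured", "known", "first", "only" and "open" are said of these compounds alone.

In a functional assay on MGC-803 cells (Homo sapiens) for cytotoxicity, read by MTT assay, with a stated time of 72 h (a lower number here means a stronger inhibitor, a higher number a weaker inhibitor), compound 1 `O=C(NC(=S)NNc1ncnc2ccccc12)c1ccc(C(F)(F)F)cc1` gives 10600 nM. Compound 2 `COc1cc2ncnc(NNC(=S)NC(=O)c3cccc(Cl)c3)c2cc1OC` gives 4060 nM, a gap from compound 1 that lies beyond the scatter, while compound 3 `COc1cc2ncnc(NNC(=S)NC(=O)c3ccccc3Cl)c2cc1OC` gives 6440 nM, which sits within the scatter of compound 1. Among the compounds with values here, the only measured step, a 1.6-fold higher number from compound 2 to compound 3 (0.20 log units; within the scatter), exchanges one chlorophenyl for another and bears only loosely on the present question, since compound 1 carries a different core. Compound 4 `O=C(NC(=S)NNc1ncnc2ccccc12)c1ccc(Cl)cc1` differs from compound 1 by chloro in place of trifluoromethyl on an aromatic carbon. Within the data shown here, no measured step tests this exchange, so no movement beyond the scatter is expected, and a 1.2-fold lower number from compound 1 to compound 4 (0.07 log units; within the scatter) is the estimated step. Compound 4 is therefore expected to give 9000 nM, within 3500 nM to 25000 nM.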

Compound 4, half-maximal inhibitory concentration: 1860 nM
Compound 4: the middle estimate sits 4.8-fold (0.68 log units) above what was measured; measured number below the stated range.
By their numbers in this assay, from the lowest: compound 4; then compounds 2, 3 and 1 (each within the scatter of the next, the first and the last beyond it).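

In this assay chloro in place of trifluoromethyl on this aromatic carbon gives a 5.7-fold lower number from compound 1 to compound 4 (0.76 log units; beyond the scatter) and so shows that the activity of this series can respond to a single exchange at this position. Within the data shown here, the earlier compounds could not show this, as their only step stayed within the scatter and involved a different place. Nothing shown here gives a reason for this step.

From the compounds shown here alone, whether an amine or a carboxylic acid at this position would move the number in either direction remains open. So does whether the same exchange would give a similar step on the core of compound 2.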